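Amide substituent change and half-life in the series

The compounds below may be only part of what the source reports. "The series", "measured", "known", "first", "only" and "open" are said of these compounds alone.

Values in an ADME assay on microsomes from liver (Mus musculus, strain CD-1) for metabolic stability, read by LC-MS, tested at 2 uM (on this read-out lower numbers stand for a shorter-lived compound and higher numbers for a longer-lived compound), for the measured compounds:

- compound 1 `Cn1ccc2ccc(-c3cc(Nc4ccccc4S(N)(=O)=O)cc4nccnc34)cc21` gives 0.5 h
- compound 2 `Cn1cc(NC(=O)c2ccncc2Nc2cc(-c3ccc4ccn(C)c4c3)c3nccnc3c2)cn1` gives 0.2 h
- compound 3 `CC(=O)N1CCC(NC(=O)c2ccncc2Nc2cc(-c3ccc4ccn(C)c4c3)c3nccnc3c2)CC1` gives 0.117 h

Compound 3 holds a smaller number than compound 1 (0.5 h) with a gap beyond the scatter, while its value stays within the scatter of compound 2 (0.2 h). It therefore cannot be separated from compound 2 on these data.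

The next compound is compound 4 `CC(=O)N1CCOC(CNC(=O)c2ccncc2Nc2cc(-c3ccc4ccn(C)c4c3)c3nccnc3c2)C1` which carries (4-acetylmorpholin-2-yl)methyl in place of 1-acetylpiperidin-4-yl on an amide-type nitrogen. Within the data shown here, no measured compound carries the entering group, so the data offer no direct precedent for it.

Among the measured compounds shown here, only one measured step changes a group at this place. That step is a 1.7-fold lower number from compound 2 to compound 3 (0.23 log units; within the scatter) and it stays within the scatter, even though the two groups exchanged there are quite different. For the measured compounds named here, compound 1 offers no step at this place. On that single step, no change beyond the scatter is expected in this assay and no direction can be argued with confidence. The expected step is a 1.1-fold higher number from compound 3 to compound 4 (0.05 log units; within the scatter) and it is small enough to be lost in repeat measurements. The estimated half-life of compound 4 is 0.13 h with an expected range of 0.07 h to 0.27 h on this estimate.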

Compound 4, half-life: 0.217 h
The estimate for compound 4 lay 1.7-fold (0.22 log units) below the measured number, within the range that was stated.
By their numbers in this assay, from the lowest: compounds 3, 2 and 4 (each within the scatter of the next); then compound 1.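

In this assay, replacing 1-acetylpiperidin-4-yl with (4-acetylmorpholin-2-yl)methyl on the amide-type nitrogen gives a 1.9-fold higher number from compound 3 to compound 4 (0.27 log units; within the scatter), and replacing 1-methyl-1H-pyrazol-4-yl with the same group gives a 1.1-fold higher number from compound 2 to compound 4 (0.04 log units; within the scatter). Among these compounds, this position now has three quite different groups joined by steps that all stay within the scatter, where the earlier compounds offered a single step, so the flat reading at this place rests on a little more than one pair, and neither the second ring oxygen nor the added methyl link of the entering group produces a step beyond the scatter here. No data at hand bear on why these readings fall as they do.

Compound 4 carries the ring oxygen and the methyl link together, so (1-acetylpiperidin-4-yl)methyl on the same nitrogen would be needed to read them apart. On these data alone, it also remains open whether any group at this place can give a step beyond the scatter, for instance a free piperidine amine without the acetyl, a carboxylic acid or a longer chain.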